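Swapping the thiophene on a purine-type series for pyrazole

This account rests on a few compounds, and the source may have more. Where it says the series, first, only, none or still open, it means among the compounds named here.

compound 1 `NC1CCC(Nc2nc(NCc3ccc(Br)cc3)c3ncn(C4CCCC4)c3n2)CC1` gives 1170 nM here
compound 2 `NC1CCC(Nc2nc(NCc3ccc(-c4ccccc4)cc3)c3ncn(C4CCCC4)c3n2)CC1` gives 530 nM here
compound 3 `NC1CCC(Nc2nc(NCc3ccc(-c4ccsc4)cc3)c3ncn(C4CCCC4)c3n2)CC1` gives 150 nM here

All three numbers come from a functional assay on K562 cells (Homo sapiens) for inhibition, with a stated time of 72 h (on this read-out higher numbers stand for weaker inhibition and lower numbers for stronger inhibition), and compound 3 has the lowest of them. Compound 4 `NC1CCC(Nc2nc(NCc3ccc(-n4cccn4)cc3)c3ncn(C4CCCC4)c3n2)CC1` has not yet been measured. It differs from compound 3 by one group, with 1H-pyrazol-1-yl in place of thiophen-3-yl on an aromatic carbon.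

The measured steps all change this same place. The change from bromo to phenyl gave a 2.2-fold lower number from compound 1 to compound 2 (0.34 log units; beyond the scatter) and the change from bromo to thiophen-3-yl gave a 7.8-fold lower number from compound 1 to compound 3 (0.89 log units; beyond the scatter). Closest to the new change is the swap of one ring for another, which gave a 3.5-fold lower number from compound 2 to compound 3 (0.55 log units; beyond the scatter) and was modest. Among the compounds with values here, no measured compound carries the 1H-pyrazol-1-yl group, so the direction is uncertain. Compound 3 already holds the lowest number, so a modest rise seems more likely than a further fall. The expected change in this assay is a 1.8-fold higher number from compound 3 to compound 4 (0.26 log units; within the scatter) as an estimate. For compound 4 the estimated value is 270 nM with an expected range from 90 nM to 800 nM in this read-out.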

Compound 4, half-maximal inhibitory concentration: 119 nM
The estimate for compound 4 lay 2.3-fold (0.36 log units) above the measured number; low and high end bracket the measured number.
By their numbers in this assay, from the lowest: compounds 4 and 3 (each within the scatter of the next); then compound 2; then compound 1.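

In this assay, the swap at this position gives a 1.3-fold lower number from compound 3 to compound 4 (0.10 log units; within the scatter) and so shows that a sulfur atom in the ring is not required for a number in this range, since a five-membered aromatic ring with 2 hetero atoms, both nitrogen, does as well. Measured against the earlier groups, 1H-pyrazol-1-yl gives a 4.5-fold lower number from compound 2 to compound 4 (0.65 log units; beyond the scatter) and a 9.8-fold lower number from compound 1 to compound 4 (0.99 log units; beyond the scatter) as well, so among these four compounds the two five-membered rings both stand apart from phenyl and bromo. Nothing available here explains why these two rings read alike.

From the compounds shown here alone, whether the count of ring nitrogens or the ring's point of attachment matters more stays open. So does the outcome with a 1H-imidazol-1-yl ring, a morpholine ring or a carboxylic acid at this position.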